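The compounds below may be only part of what the source reports. "The series", "measured", "known", "first", "only" and "open" are said of these compounds alone.

Compound 1 `CN(C(=O)c1c(O)c2c(C(F)(F)F)cccc2n(C)c1=O)c1ccccc1` is the reference point of the series. In a functional assay on the whole organism for inhibition, with Mus musculus as the target, at a dose of 1 mg/kg by the oral route (on this read-out lower numbers stand for less inhibition and higher numbers for more inhibition at the one dose given (going by the name of the read-out)), compound 1 gives 99%, the highest of the two numbers recorded so far. Compound 2 `CCN(C(=O)c1c(O)c2c(C(F)(F)F)cccc2n(C)c1=O)c1ccccc1` differs from it by methyl in place of hydrogen on a saturated chain carbon bound to an amide-type nitrogen; in this assay compound 2 gives 80%, which is a step of a number 19 percentage points lower from compound 1 to compound 2 (beyond the scatter). Compound 3 `CCOc1cccc2c1c(O)c(C(=O)N(C)c1ccccc1)c(=O)n2C` has not yet been measured. Relative to compound 1 it carries ethoxy in place of trifluoromethyl on an aromatic carbon. Among the measured compounds shown here, the single measured step concerns the substituent on the amide-type nitrogen and leaves the fused ring system untouched, so no measured step bears on this change; the data contain no other replacement of the trifluoromethyl group. What can be said is that compound 1 sits close to the top of the read-out, so any step from it in this assay can only be downward or within the scatter. Without a guide from the series, the expected step of a number 29 percentage points lower from compound 1 to compound 3 (beyond the scatter) is set as a moderate loss with a wide range. Compound 3 is estimated at 70%, with a range from 35% to 99%.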

Compound 3, a percentage reported as inhibition, in the whole organism at one dose (the size of the read-out at that dose, not a potency): 40%
The estimate for compound 3 lay 30 percentage points above the measured number, within the range that was stated.
By their numbers in this assay, from the lowest: compound 3; then compound 2; then compound 1.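

In this assay, ethoxy in place of trifluoromethyl on an aromatic carbon gives a number 59 percentage points lower from compound 1 to compound 3 (beyond the scatter), so the read-out does not hold up under every substituent at this place, ortho to a fused ring. Read beside a number 19 percentage points lower from compound 1 to compound 2 (beyond the scatter), which concerns only the substituent on the amide-type nitrogen, this new step shows that the read-out responds to a change on the aromatic ring as well as to one on that nitrogen. The entering ethoxy carries a hydrogen-bond acceptor and the leaving trifluoromethyl carries none, but no measurement available here connects that difference, or any other feature of the two groups, with the loss.

With one replacement at this carbon, the series cannot tell whether the loss is particular to ethoxy or follows from removing trifluoromethyl; methoxy, chlorine or plain hydrogen at the same place would help separate these two readings. Going by these compounds, it also remains open whether the ethyl group on the amide-type nitrogen of compound 2 would produce a similar step when combined with ethoxy on the ring.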